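A few compounds are considered here, and "the series" means these few. Any claim that something is new, unique, unknown or untested is made for them only; others in the source may bear on it.

This set of compounds shares one core, a bridged ketone, carrying a triazole that is linked to a benzyl or alkyl group. Compound 1 `COc1ccc(Cn2cc(CO[C@H]3CC(=O)[C@@H]4OC[C@H]3O4)nn2)cc1` gives 34800 nM in a functional assay on MDA-MB-231 cells (Homo sapiens) for cytotoxicity, read by MTT assay, with a stated time of 48 h; on this read-out lower numbers stand for stronger inhibition and higher numbers for weaker inhibition. Compound 2 `O=C1C[C@H](OCc2cn(Cc3ccc([N+](=O)[O-])cc3)nn2)[C@H]2CO[C@@H]1O2` gives 25400 nM in this assay; the change from compound 1 to compound 2 is a 1.4-fold lower number from compound 1 to compound 2 (0.14 log units; within the scatter). Compound 3 `CC(=O)N(Cc1cn(Cc2ccccc2)nn1)[C@H]1CC(=O)[C@@H]2OC[C@H]1O2` stands apart: in this assay compound 3 gives only a limit of the assay, > 50000 nM, so its true number is not known, and it is one of the values at the limit of > 50000 nM in this assay, at which 1 of the 3 values shown sits.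

Compound 4 `CCCCCCCCn1cc(CN(C(C)=O)[C@H]2CC(=O)[C@@H]3OC[C@H]2O3)nn1` differs from compound 3 in one place: heptyl in place of phenyl on a saturated chain carbon bound to an aromatic nitrogen, so that a benzyl group becomes an octyl chain. Among the compounds with values here, no measured step between these compounds concerns this kind of exchange; the only measured step, from compound 1 to compound 2, changes a substituent on an aromatic ring and lies within the scatter, so it says nothing about swapping a ring for a chain. With compound 3 known only as a limit, the expected outcome for compound 4 is that it too most likely remains at or near the limit, with the estimated step being a number no higher from compound 3 to compound 4 (the limit leaves the size open). The estimate for compound 4 in this assay is therefore 50000 nM, with a range from 15000 nM to 160000 nM.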

Compound 4, half-maximal inhibitory concentration: > 50000 nM
Compound 4: only a limit was reported; the forecaster's own chance of this, stated with the estimate: 60%; the middle value lies on the limit itself.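

Compound 3 and compound 4 each reach only a limit in this assay, so no step can be read between them, and the change from benzyl to octyl has no readable size: the limit of > 50000 nM in this assay, at which 2 of the 4 values shown sit. The compounds shown leave open where the true values of compound 3 and compound 4 lie beyond that limit.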